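A few compounds are considered here, and "the series" means these few. Any claim that something is new, unique, unknown or untested is made for them only; others in the source may bear on it.

Of the compounds shown here, three of a shared core have been measured in an assay on HEK293 cells for inhibition of N-acylethanolamine-hydrolyzing acid amidase (Rattus norvegicus), read by LC-MS, with a stated time of 30 min; a higher number here means a weaker inhibitor, a lower number a stronger inhibitor. Compound 1 `O=C(CCCCCc1cccc(I)c1)N1CCOC1=O` gives 3120 nM in this assay, compound 2 `O=C(CCCCCc1ccc(O)c(F)c1)N1CCOC1=O` gives 160 nM, and compound 3 `O=C(CCCCCc1ccc(Br)cc1)N1CCOC1=O` gives 8510 nM. Compound 3 stands at the highest number of the three: the nearest neighbour is compound 1, whose number lies beyond the scatter below it, and the furthest is compound 2, whose number lies far below it, also beyond the scatter. Compound 4 `COc1ccc(CCCCCC(=O)N2CCOC2=O)cc1` has not yet been measured in this assay. It differs from compound 3 in one place: methoxy in place of bromo on an aromatic carbon. Going by the values given here, no step between two measured compounds that differ in only one place is available, so the size of this change has to be judged from the three numbers alone. Compound 2 carries an oxygen-bearing group on the ring and gives the lowest number of the set, while compound 3 with bromo gives the highest; compound 4 carries an oxygen-bearing group, a methoxy, at the place where compound 3 has bromo. On that basis compound 4 is expected to move downward in this assay, by a 5.7-fold lower number from compound 3 to compound 4 (0.75 log units; beyond the scatter), a step expected to lie beyond the scatter. Compound 4 is estimated at 1500 nM, within a range of 400 nM to 6000 nM.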

Compound 4, half-maximal inhibitory concentration: > 20000 nM
Compound 4: only a limit was reported; the forecaster's own chance of this, stated with the estimate: 5%; at least 13-fold (1.12 log units) between middle value and limit.
By their numbers in this assay, from the lowest: compound 2; then compound 1; then compound 3. At a limit, above all of these: compound 4.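

Compound 4 gives > 20000 nM in this assay, and this value is a limit of the assay, not a number. Methoxy in place of bromo on an aromatic carbon, para to a large group, provides the first one-place comparison in the set and gives an at least 2.3-fold higher number from compound 3 to compound 4 (0.37 log units; beyond the scatter), so this position on the ring is sensitive to which group it carries, and a methoxy there brings no gain over bromo. The step has only a lower bound, and how far compound 4 lies from compound 3 cannot be read, as the reading ends at a limit: the limit of > 20000 nM in this assay, at which 1 of the 4 values shown sits.

The compounds shown leave open how a hydroxy, an amine or a chloro at this same place would compare with bromo and methoxy, and whether methoxy in place of the iodo of compound 1 would move the number in the same direction. They also leave open whether a shorter or longer chain on the shared core would change the effect of this exchange.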